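Replacing the amide side chain of compound 2

This account rests on a few compounds, and the source may have more. Where it says the series, first, only, none or still open, it means among the compounds named here.

Measured in a functional assay on MCF7 cells (Homo sapiens) for antiproliferative activity, read by MTT assay, with a stated time of 72 h (a lower number here means a stronger inhibitor, a higher number a weaker inhibitor), so far

compound 1 `CCn1c(C(=O)NCC(=O)O)ccc1C(CC)(CC)c1ccc(C#CC(O)(CC)CC)c(C)c1` gives 5140 nM
compound 2 `CCN(CC)CCNC(=O)c1cc(C(CC)(CC)c2ccc(C#CC(O)(CC)CC)c(C)c2)cn1CC` gives 1800 nM

Of these two, compound 2 has the lower number (1800 nM), set against compound 1 (5140 nM). The gap between them lies beyond the scatter. Compound 3 `CCn1cc(C(CC)(CC)c2ccc(C#CC(O)(CC)CC)c(C)c2)cc1C(=O)OCCO` carries 2-hydroxyethoxy in place of (2-(diethylamino)ethyl)amino on a carbonyl carbon and remains unmeasured. Within the data shown here, no measured pair isolates this change, so the expectation is tentative. Compound 1 (5140 nM) also lacks the (2-(diethylamino)ethyl)amino group and sits higher. A moderate rise in this assay is therefore expected, an estimated 2.2-fold higher number from compound 2 to compound 3 (0.35 log units; beyond the scatter) in all. The estimate for compound 3 is 4000 nM (range 1500 nM to 11000 nM).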

Compound 3, half-maximal inhibitory concentration: 1880 nM
The estimate for compound 3 lay 2.1-fold (0.33 log units) above the measured number; low and high end bracket the measured number.
By their numbers in this assay, from the lowest: compounds 2 and 3 (each within the scatter of the next); then compound 1.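

In this assay, setting 2-hydroxyethoxy in place of (2-(diethylamino)ethyl)amino on a carbonyl carbon gives a 1.0-fold higher number from compound 2 to compound 3 (0.02 log units; within the scatter). At this position, then, neither the diethylamino group nor the amide hydrogen is needed to keep the number where it stands, and the shorter ester chain serves equally well. Nothing available accounts for this match.

From the compounds shown here alone, what remains open is how far this tolerance extends. A free carboxylic acid, a simple methyl ester or a longer chain ending in a hydroxyl group on the same carbonyl carbon could each still behave differently.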